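Swapping piperidin-4-yl for methyl on a second core

The compounds below may be only part of what the source reports. "The series", "measured", "known", "first", "only" and "open" are said of these compounds alone.

Compound 1 `CC(Nc1ncnc2ncc(-c3cnn(C4CCNCC4)c3)cc12)c1c(Cl)ccc(F)c1Cl` carries a piperidin-4-yl group on an aromatic nitrogen, and in a functional assay on A549 cells (Homo sapiens) for antiproliferative activity, read by MTT assay, with a stated time of 72 h (on this read-out higher numbers stand for weaker inhibition and lower numbers for stronger inhibition), compound 1 gives 29700 nM. Compound 2 `CC(Nc1ncnc2ncc(-c3cnn(C)c3)cc12)c1c(Cl)ccc(F)c1Cl` differs from it in one place: methyl in place of piperidin-4-yl on an aromatic nitrogen. In this assay compound 2 reaches only a limit of the assay, > 100000 nM. The change is therefore measured as an at least 3.3-fold higher number from compound 1 to compound 2 (0.52 log units; beyond the scatter), and because the limit of > 100000 nM in this assay, at which 1 of the 3 values shown sits, the step is known only as a lower bound.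

Compound 3 `c1cnc2ccc(Nc3ncnc4ccc(-c5cnn(C6CCNCC6)c5)cc34)cc2c1` sits on a different core; the difference between the two cores is not broken down here. In this assay compound 3 gives 32000 nM, a number that lies within the usual scatter of that of compound 1. Compound 4 `Cn1cc(-c2ccc3ncnc(Nc4ccc5ncccc5c4)c3c2)cn1` is the partner of compound 3 made by the same change as before, (methyl in place of piperidin-4-yl on an aromatic nitrogen), with the place described in the same words in both pairs.

Going by the values given here, for compound 4 the expectation rests on the one measured example of this change, the step of an at least 3.3-fold higher number from compound 1 to compound 2 (0.52 log units; beyond the scatter), and on compound 3 starting from 32000 nM. The step from compound 3 to compound 4 is expected to be a 3.4-fold higher number from compound 3 to compound 4 (0.54 log units; beyond the scatter), toward weaker inhibition. In this assay compound 4 is accordingly estimated at 110000 nM, plausibly between 45000 nM and 400000 nM, with a real chance that only a limit is reported.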

Compound 4, half-maximal inhibitory concentration: 1380 nM
Estimate against measurement, compound 4: 80-fold (1.90 log units) above, outside the stated range (below it).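

In this assay the same change on the second core gives a 23-fold lower number from compound 3 to compound 4 (1.37 log units; beyond the scatter), so the direction seen on the first core does not carry over, and the two steps clearly differ: the same change on two cores in this assay, an at least 3.3-fold higher number (0.52 log units; beyond the scatter) from compound 1 to compound 2 and a 23-fold lower number (1.37 log units; beyond the scatter) from compound 3 to compound 4, at least 78-fold (1.89 log units) apart, beyond the scatter of two such steps

The step on the first core is known only as a lower bound, with compound 2 reported at a limit of the assay rather than at a number: the limit of > 100000 nM in this assay, at which 1 of the 4 values shown sits.

Going by these compounds alone, the two pairs show that the result of replacing piperidin-4-yl with methyl depends on the core that carries it, but with only one pair on each core they do not show what in the cores is responsible, nor whether either direction would hold for other compounds built on these cores.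

Going by these compounds, whether an ethyl group or a short chain ending in an amine on the same aromatic nitrogen would follow the pattern of the first core or of the second stays open. Also open, on these data alone, is which part of the difference between the two cores goes with the reversal of direction.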